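This account rests on a few compounds, and the source may have more. Where it says the series, first, only, none or still open, it means among the compounds named here.

Compound 1, `O=C(Nc1ccccc1)c1cccc(Br)c1O`, gives in an assay on isolated protein for inhibition of thiosulfate sulfurtransferase (Homo sapiens), with a stated time of 60 min, in the absence of a further agent (a higher number here means a weaker inhibitor, a lower number a stronger inhibitor), only a limit, > 100000 nM.
Compound 2, `O=C(Nc1ccc(Sc2nc3ccccc3s2)cc1)c1cccc(Br)c1`, gives in this assay only a limit, > 100000 nM.
Compound 3, `O=C(Nc1cccc(Cl)c1)c1cccc(Br)c1O`, gives in this assay only a limit, > 100000 nM.

Compound 1 thus stands nowhere definite on the numbers shown: its value is a limit, and the two other values are limits as well, so it cannot be ranked against compound 2 or compound 3. The unmeasured compound 4, `O=C(Nc1ccccc1)c1cccc(Br)c1`, differs from compound 1 in one place: hydrogen in place of hydroxy on an aromatic carbon. Within the data shown here, the one measured step, a step that the two limits leave unreadable from compound 1 to compound 3, is unreadable; both of its ends sit at the limit of > 100000 nM in this assay, at which 3 of the 3 values shown sit. No readable step therefore bears on the change to compound 4, and the only expectation is that it stays where its neighbours sit. Compound 4 is expected to give about 150000 nM, within 50000 nM to 1000000 nM, most likely reported again as a limit. The step this estimate means, a step that the limit leaves unreadable from compound 1 to compound 4, is expected to be no change beyond the scatter.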

Compound 4, half-maximal inhibitory concentration: > 100000 nM
Compound 4: no number, only a limit (the forecaster's own chance of this, stated with the estimate: 85%); the middle value does not contradict the limit.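

No step can be read between compound 1 and compound 4, since both carry only a limit: the limit of > 100000 nM in this assay, at which 4 of the 4 values shown sit.
The compounds shown leave open whether the hydroxy group matters at all, and whether any change to the shared core gives a readable value.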